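The source may hold more compounds than are shown below. What is called first, only, known or untested is meant among the compounds shown, and "the series" means these compounds.

Measured compounds:
compound 1, `O=C(CCc1ccc(-c2cccc(F)c2)cc1)N1CCCC1`: 1800 nM
compound 2, `O=C(CCc1ccc(-c2cccnc2)cc1)N1CCCC1`: > 100000 nM (a limit, not a number)
compound 3, `O=C(CCc1ccc(-c2ccsc2)cc1)N1CCCC1`: 2500 nM

In an assay on HEK293 cells for inhibition of N-acylethanolamine-hydrolyzing acid amidase (Rattus norvegicus), read by LC-MS, with a stated time of 30 min (on this read-out higher numbers stand for weaker inhibition and lower numbers for stronger inhibition), compound 1 gives 1800 nM. For compound 2 the read-out stops at the limit of > 100000 nM in this assay, at which 1 of the 3 values shown sits, so only a limit and no number is known for it. Compound 3 gives 2500 nM and so carries the highest of the two numbers, yet the step of a 1.4-fold higher number from compound 1 to compound 3 (0.14 log units; within the scatter) lies within the scatter, so compound 1 and compound 3 cannot be told apart. The two steps that involve the pyridine ring are large: an at least 55-fold higher number from compound 1 to compound 2 (1.74 log units; beyond the scatter) and an at least 40-fold lower number from compound 2 to compound 3 (1.60 log units; beyond the scatter).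

Compound 4, `O=C(CCc1ccc(OC2CCCCC2)cc1)N1CCCC1`, differs from compound 3 by a single change: cyclohexyloxy in place of thiophen-3-yl on an aromatic carbon. Going by the values given here, none of the measured steps swaps an aromatic ring for a non-aromatic ether, so no step bears directly on it. The swap from 3-fluorophenyl to thiophen-3-yl stayed within the scatter, while the swap to pyridin-3-yl cost a great deal; the present change is of a different kind from both. The expectation is therefore a step of a 1.2-fold higher number from compound 3 to compound 4 (0.08 log units; within the scatter) in this assay, with wide uncertainty. For compound 4 the estimate is 3000 nM, in a range from 700 nM to 15000 nM.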

Compound 4, half-maximal inhibitory concentration: 700 nM
Estimate against measurement, compound 4: 4.3-fold (0.63 log units) above; low and high end bracket the measured number.
By their numbers in this assay, from the lowest: compound 4; then compounds 1 and 3 (each within the scatter of the next). At a limit, above all of these: compound 2.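

In this assay, going by these compounds alone, this position, on an aromatic carbon para to a group of 9 heavy atoms, had so far held only aromatic rings, and compound 4 shows that an aromatic ring is not needed there: cyclohexyloxy, a six-membered non-aromatic ring of carbon only attached through oxygen, gives a 3.6-fold lower number from compound 3 to compound 4 (0.55 log units; beyond the scatter) and a 2.6-fold lower number from compound 1 to compound 4 (0.41 log units; beyond the scatter). Both steps are modest but beyond the scatter, so compound 4 stands apart from compound 1 and compound 3, which cannot be told apart from each other, and it has the lowest number of the compounds shown. The widest gap is an at least 140-fold lower number from compound 2 to compound 4 (2.15 log units; beyond the scatter), and it starts from a limit rather than a number: the limit of > 100000 nM in this assay, at which 1 of the 4 values shown sits.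

Cyclohexyloxy differs from thiophen-3-yl in its ring type, in its linking oxygen and in its count of heavy atoms all at once, so the compounds shown cannot say which of these differences matters. A cyclohexyl group without the oxygen, a cyclopentyloxy group, or a phenoxy group, which keeps the oxygen but restores an aromatic ring, would help separate them.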